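Bromine on the Central Phenyl of a Bis-Cinnamoyl Scaffold

The source may report more compounds than this note shows. Statements on the series, on what has been measured and on what is new or still open speak of the compounds shown alone.

Compound 1 `Cc1cc(O)c(C(=O)/C=C/c2ccccc2)c(-c2ccccc2)c1C(=O)/C=C/c1ccccc1` carries two cinnamoyl arms on a shared core. In a functional assay on MDA-MB-231 cells (Homo sapiens) for cytotoxicity, read by MTT assay, with a stated time of 24 h (on this read-out lower numbers stand for stronger inhibition and higher numbers for weaker inhibition), compound 1 gives 8500 nM, the lower of the two numbers reported; its nearest neighbour, compound 2 `Cc1cc(O)c(C(=O)/C=C/c2ccc(F)cc2)c(-c2ccccc2)c1C(=O)/C=C/c1ccc(F)cc1`, gives 20000 nM, a gap beyond the usual scatter. Compound 3 `COc1ccc(/C=C/C(=O)c2c(C)cc(O)c(C(=O)/C=C/c3ccc(OC)c(OC)c3)c2-c2ccccc2)cc1OC` is recorded in this assay as "not active" (no number reported). Compound 4 `Cc1cc(O)c(C(=O)/C=C/c2ccccc2)c(-c2ccc(Br)cc2)c1C(=O)/C=C/c1ccccc1` differs from compound 1 by bromo in place of hydrogen on an aromatic carbon, a bromo in place of hydrogen on an aromatic carbon, para to a large group. Among the measured compounds shown here, no measured pair shows a change of this kind, so no direction can be read from the data. The step of a 1.1-fold lower number from compound 1 to compound 4 (0.03 log units; within the scatter) is expected to stay within the scatter, or only a little beyond it. In this assay compound 4 is expected at 8000 nM, with a range from 3000 nM to 25000 nM.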

Compound 4, half-maximal inhibitory concentration: 8000 nM
Compound 4: middle estimate and measured number agree at the digits printed; low and high end bracket the measured number.
By their numbers in this assay, from the lowest: compounds 4 and 1 (each within the scatter of the next); then compound 2.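

In this assay, the change from phenyl to 4-bromophenyl gives a 1.1-fold lower number from compound 1 to compound 4 (0.03 log units; within the scatter). This is the first pair shown that differs in one place, and it shows that a bromo on this aromatic carbon, para to a large group, leaves the number of compound 1 within the usual scatter. Nothing given here accounts for this outcome.

Going by these compounds, whether an amine, a carboxylic acid or a methoxy group on the same carbon would also leave the number within the scatter stays open. So does the outcome for a bromo on the cinnamoyl arms.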